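Benzyl change in the ester-linked series, one step

The source may report more compounds than this note shows. Statements on the series, on what has been measured and on what is new or still open speak of the compounds shown alone.

Compound 2 `C=C1C(=O)O[C@H]2[C@H]1CC/C(COC(=O)Cn1cc(F)c(=O)n(Cc3ccc(C(F)(F)F)cc3)c1=O)=C\CC[C@@]1(C)O[C@@H]21` is the reference point. In a functional assay on Bel7402/5-FU cells (Homo sapiens) for antiproliferative activity, read by MTT assay, with a stated time of 72 h (on this read-out lower numbers stand for stronger inhibition and higher numbers for weaker inhibition), compound 2 gives 2250 nM. Compound 1 `C=C1C(=O)O[C@H]2[C@H]1CC/C(COC(=O)CCC(=O)N1CCN(C(=O)Cn3cc(F)c(=O)n(Cc4ccccc4)c3=O)CC1)=C\CC[C@@]1(C)O[C@@H]21` in this assay reaches only > 20000 nM, which is a limit of the assay and not a number; this is the point where the limit of > 20000 nM in this assay, at which 1 of the 2 values shown sits, sits. Among the measured compounds shown here, compound 2 therefore holds the only numerical value shown in this assay, and the remaining value is a limit, so its standing can be stated only against that limit.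

Compound 3 `C=C1C(=O)O[C@H]2[C@H]1CC/C(COC(=O)Cn1cc(F)c(=O)n(Cc3cc(F)ccc3F)c1=O)=C\CC[C@@]1(C)O[C@@H]21` differs from compound 2 in one place: 2,5-difluorophenyl in place of 4-(trifluoromethyl)phenyl on a saturated chain carbon bound to an aromatic nitrogen. For the measured compounds named here, no pair of measured compounds differs in a single place, so no measured step of comparable kind is available to anchor the expectation, and the two values that do exist cannot be turned into a step. The change keeps the same aromatic ring and the same donor and acceptor count, so the step from compound 2 to compound 3 in this assay is expected to be a 1.3-fold higher number from compound 2 to compound 3 (0.12 log units; within the scatter), a move not clearly beyond the usual scatter, with no firm direction. Compound 3 is expected at 3000 nM in this assay, with a range from 1000 nM to 9000 nM.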

Compound 3, half-maximal inhibitory concentration: 4610 nM
Beside the measured number, compound 3's estimate is 1.5-fold (0.19 log units) below it, and the stated range covers the measured number.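

At the saturated chain carbon bound to an aromatic nitrogen, the series now has its first readable step in this assay: 2,5-difluorophenyl in place of 4-(trifluoromethyl)phenyl gives a 2.0-fold higher number from compound 2 to compound 3 (0.31 log units; beyond the scatter), a modest move. This position therefore responds to a change of the aromatic substituents, even though the ring stays a six-membered aromatic ring of carbon only and neither group brings a hydrogen-bond donor, a hydrogen-bond acceptor or a net charge. No measurement shown here bears on what lies behind this step.

As far as these compounds go, with a single step, it stays open whether the number follows the trifluoromethyl group, the two fluorines or their placing, and how a plain benzyl, a methoxybenzyl, or a benzyl carrying an amine or a carboxylic acid would read at this place on the ester-linked core. From the compounds shown here alone, a longer chain between the aromatic nitrogen and the phenyl ring is equally open, as is whether the size of this step would hold on a different linker.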